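A few compounds are considered here, and "the series" means these few. Any claim that something is new, unique, unknown or untested is made for them only; others in the source may bear on it.

Series on the shared core of compound 2 `CC(=O)Nc1ccc(S(=O)(=O)Oc2ccccc2C(C)C)cc1`, compound 3 `CC(=O)Nc1ccc(S(=O)(=O)Oc2ccccc2I)cc1` and compound 1 `CC(C)c1ccccc1OS(=O)(=O)c1cccc(NC(=O)CCl)c1`. In a functional assay on M21 cells (Homo sapiens) for antiproliferative activity, read by sulforhodamine B assay, with a stated time of 48 h (on this read-out lower numbers stand for stronger inhibition and higher numbers for weaker inhibition), compound 2 gives 21000 nM, compound 3 gives 27000 nM and compound 1 gives 3900 nM. Compound 2 stands second highest of the three numbers, nearest to compound 3 and furthest from compound 1. Among the measured compounds shown here, the only single-place step so far, a 1.3-fold higher number from compound 2 to compound 3 (0.11 log units; within the scatter), swaps a group on an aromatic carbon, not on a carbonyl carbon. Compound 4 `CC(C)C(=O)Nc1ccc(S(=O)(=O)Oc2ccccc2C(C)C)cc1` differs from compound 2 by isopropyl in place of methyl on a carbonyl carbon. For the measured compounds named here, no measured step touches the carbonyl carbon, so in this assay no step beyond the scatter is expected from this change. Compound 4 is therefore estimated at 21000 nM, in a range of 8000 nM to 50000 nM, which means an expected step of no change at the digits printed from compound 2 to compound 4 (within the scatter).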

Compound 4, half-maximal inhibitory concentration: 11000 nM
Compound 4: the middle estimate sits 1.9-fold (0.28 log units) above what was measured; the range from low to high includes it.
By their numbers in this assay, from the lowest: compound 1; then compounds 4, 2 and 3 (each within the scatter of the next, the first and the last beyond it).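

In this assay, the change on the carbonyl carbon, acetamido to (isopropylcarbonyl)amino, gives a 1.9-fold lower number from compound 2 to compound 4 (0.28 log units; within the scatter), so this position accepts isopropyl in place of methyl without a step beyond the scatter. No measured data bear on the reason for this result. As far as these compounds go, whether a longer chain, an amine or a carboxylic acid on the carbonyl carbon would also stay within the scatter remains open. Also open, from the compounds shown here alone, is whether isopropyl in place of methyl gives a similar step with iodo on the aromatic carbon.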